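The source may hold more compounds than are shown below. What is called first, only, known or untested is meant among the compounds shown, and "the series" means these compounds.

Of the compounds shown here, three have been measured in a physicochemical assay for solubility, at pH 7; a lower number here means a less soluble compound, a higher number a more soluble compound. Compound 1 `CCc1ccccc1Nc1ncc2cc(Oc3ccnc(C(=O)NC)c3)ccc2n1` gives only a limit there, < 1000 nM. Compound 2 `CNC(=O)c1cc(Oc2ccc3nc(Nc4cccc(Cl)c4)ncc3c2)ccn1` also gives a limit, < 1000 nM. Compound 3 `CNC(=O)c1cc(Oc2ccc3nc(Nc4cccc(Br)c4)ncc3c2)ccn1` likewise sits at a limit, < 1000 nM. The steps among them, a step that the two limits leave unreadable from compound 1 to compound 2, a step that the two limits leave unreadable from compound 1 to compound 3 and a step that the two limits leave unreadable from compound 2 to compound 3, are unreadable in size, since all three values sit at the limit of < 1000 nM in this assay, at which 3 of the 3 values shown sit. Compound 4 `CNC(=O)c1cc(Oc2ccc3nc(Nc4cccc(C(C)C)c4)ncc3c2)ccn1` differs from compound 3 by isopropyl in place of bromo on an aromatic carbon. Among the compounds with values here, no measured step bears on this particular change, and none of the three measured steps reads as a number, so neither direction nor size can be drawn from them. Within the data shown here, compound 3 stands at the limit, and nothing measured so far points away from it. Compound 4 is expected to stay near that limit, with a step that the limit leaves unreadable from compound 3 to compound 4. Compound 4 is therefore estimated at 600 nM, in a range from 100 nM to 3000 nM, with a fair chance that this assay again reports only a limit.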

Compound 4, solubility: < 1000 nM
Compound 4: only a limit was reported (the forecaster's own chance of this, stated with the estimate: 65%); the middle value does not contradict the limit.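

The steps linking compound 4 with compound 1, compound 2 and compound 3 cannot be read in this assay, since each compound gives only a limit: the limit of < 1000 nM in this assay, at which 4 of the 4 values shown sit.

The compounds shown leave open how far each lies from that limit, and whether swapping these groups changes this assay at all.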